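Working notes on compound 4 of the series

The source may hold more compounds than are shown below. What is called first, only, known or untested is meant among the compounds shown, and "the series" means these compounds.

Measured in an in vitro assay on Sf9 cells for inhibition of leukotriene A-4 hydrolase (Homo sapiens), read by immunoassay, with stated times of 10 min and 30 min; on this read-out lower numbers stand for stronger inhibition and higher numbers for weaker inhibition:
compound 1 `c1ccc2sc(Oc3ccc4oc(CN5CCCCC5)cc4c3)nc2c1`: 330 nM
compound 2 `c1ccc2sc(Oc3ccc4c(CN5CCCCC5)coc4c3)nc2c1`: 67 nM
compound 3 `c1cnc2nc(Oc3ccc4oc(CN5CCCCC5)cc4c3)sc2c1`: 66 nM

Among these three, compound 2 has the second highest number; its value and that of compound 3 sit within the scatter of each other, while compound 1 stands beyond the scatter above it. Compound 4 `CC(=O)NC1CCN(Cc2coc3cc(Oc4nc5ccccc5s4)ccc23)CC1` carries the change (acetamido in place of hydrogen on a saturated ring carbon), that is, acetamido in place of hydrogen on a saturated ring carbon; read one bond further out, piperidin-1-yl becomes 4-acetamidopiperidin-1-yl. Among the measured compounds shown here, no measured pair in the set shows the effect of a group on this ring, so the expectation in this assay rests only on the unchanged remainder of compound 2. The expected step is a 1.3-fold lower number from compound 2 to compound 4 (0.13 log units; within the scatter), small and towards a lower number, not clearly beyond the scatter. Compound 4 is estimated at 50 nM, with a range from 15 nM to 200 nM.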

Compound 4, half-maximal inhibitory concentration: 26 nM
Beside the measured number, compound 4's estimate is 1.9-fold (0.28 log units) above it, and the stated range covers the measured number.
By their numbers in this assay, from the lowest: compound 4; then compounds 3 and 2 (each within the scatter of the next); then compound 1.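

Among the compounds shown here, the change from piperidin-1-yl to 4-acetamidopiperidin-1-yl gives a 2.6-fold lower number from compound 2 to compound 4 (0.41 log units; beyond the scatter) in this assay and is the first measured change on this ring. This saturated ring carbon therefore accepts an acetamido group, with a number lower than that of the hydrogen-bearing parent by more than the scatter. No supporting measurement here explains the step.

This single pair leaves open whether the carbonyl or the amide hydrogen matters. It also leaves open whether a free amine, a carboxylic acid or a longer acyl chain on this ring carbon would give a similar step.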